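Urea series: replacing the fluoroindazole ring of compound 1

The source may hold more compounds than are shown below. What is called first, only, known or untested is meant among the compounds shown, and "the series" means these compounds.

Compound 1 `O=C(Nc1ccc(-n2ncc3c(F)cccc32)cc1)Nc1ccc(Cl)c(C(F)(F)F)c1` is the weakest of the three measured compounds in a functional assay on Bel-7402 cells (Homo sapiens) for cytotoxicity, read by MTT assay, with a stated time of 72 h (a lower number here means a stronger inhibitor, a higher number a weaker inhibitor), where compound 1 gives 16000 nM. Among the compounds with values here, compound 2 `COc1cccc2c1cnn2-c1ccc(NC(=O)Nc2ccc(Cl)c(C(F)(F)F)c2)cc1` carries a methoxy group in place of the fluoro group on the indazole ring, and compound 2 gives 2900 nM; the step of a 5.5-fold lower number from compound 1 to compound 2 (0.74 log units; beyond the scatter) is the only single-point change available so far. Compound 3 `O=C(Nc1ccc(-n2ncc3c(Cl)cccc32)cc1)Nc1ccc(C(F)(F)F)cc1` differs from compound 1 in two places, and compound 3 gives 8000 nM, a number that lies within the scatter of compound 1.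

Compound 4 `O=C(Nc1ccc(-n2ncc3ccncc32)cc1)Nc1ccc(Cl)c(C(F)(F)F)c1` is not yet measured. Relative to compound 1 it shows (a group of 9 heavy atoms (6 carbon, 3 nitrogen; one five-membered aromatic ring with 2 hetero atoms, one six-membered aromatic ring with 1 hetero atom) in place of a group of 10 heavy atoms (7 carbon, 2 nitrogen, 1 fluorine; one five-membered aromatic ring with 2 hetero atoms, one six-membered aromatic ring of carbon only), on an aromatic carbon); the group that leaves is 4-fluoro-1H-indazol-1-yl, the group that enters has no common name, and the place is on an aromatic carbon of a six-membered aromatic ring of carbon only, para to a large group. Within the data shown here, no measured step covers this change directly. Among the measured compounds shown here, the one step on the same ring, from compound 1 to compound 2, was of modest size, so a modest change is expected in this assay, most likely toward a lower number, and the expected step is a 1.8-fold lower number from compound 1 to compound 4 (0.25 log units; within the scatter). Compound 4 is estimated at 9000 nM, with a range from 3000 nM to 27000 nM.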

Compound 4, half-maximal inhibitory concentration: 4000 nM
The estimate for compound 4 lay 2.3-fold (0.35 log units) above the measured number, and the stated range covers the measured number.
By their numbers in this assay, from the lowest: compounds 2, 4, 3 and 1 (each within the scatter of the next, the first and the last beyond it).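

Working notes on the position: in this assay, the step of a 4.0-fold lower number from compound 1 to compound 4 (0.60 log units; beyond the scatter) shows that this position tolerates more than a swap of the substituent on the carbon-only ring, since here the six-membered ring itself changes, gaining 1 hetero atom, and the fluoro group is gone. Set beside a 5.5-fold lower number from compound 1 to compound 2 (0.74 log units; beyond the scatter), it gives a second change at the 4-fluoro-1H-indazol-1-yl group that lowers the number beyond the scatter, so in these two cases the fluoro-bearing group of compound 1 is not needed for the activity seen, and both replacements do better than it. No measurement available here explains why the number falls in either step.

The step from compound 1 to compound 4 alters the ring atoms and removes the fluoro group together, so the share of each stays unresolved, and a hydrogen in place of the fluoro group on the carbon-only ring would separate them. Also open, as far as these compounds go, is how an amine or a carboxylic acid at this place would read, and whether any of these changes carries over to the urea partner with the chloro and trifluoromethyl groups altered.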